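The source may report more compounds than this note shows. Statements on the series, on what has been measured and on what is new or still open speak of the compounds shown alone.

The shared core runs through compound 1 `CC[C@@H]1C(=O)N(C)c2cnc(-n3ccnc3-c3ccc(F)cc3)nc2N1[C@H]1CCOC1`, compound 2 `CC[C@@H]1C(=O)N(C)c2cnc(-n3ccnc3-c3ccc(F)cc3)nc2N1CCC(F)(F)F` and compound 3 `CC[C@@H]1C(=O)N(C)c2cnc(-n3ccnc3-c3ccccc3)nc2N1CCC(F)(F)F`. In a physicochemical assay for lipophilicity (a lower number here means a more polar compound, a higher number a more lipophilic compound), compound 2 gives 3.1, and compound 3 gives 3.1, while compound 1 gives 2. The change oxolan-3-yl in place of 3,3,3-trifluoropropyl on a nitrogen on an aromatic ring in a ring brought a number 1.10 log units lower from compound 2 to compound 1 (beyond the scatter). The two cores differ by hydrogen in place of fluoro on an aromatic carbon, which gave no change at the digits printed from compound 2 to compound 3 (within the scatter). Compound 4 `CC[C@@H]1C(=O)N(C)c2cnc(-n3ccnc3-c3ccccc3)nc2N1[C@H]1CCOC1` has not yet been measured in this assay. It arises from compound 3 by oxolan-3-yl in place of 3,3,3-trifluoropropyl on a nitrogen on an aromatic ring in a ring, the same change that was made from compound 2 to compound 1, at the same place on the ring. Resting on a number 1.10 log units lower from compound 2 to compound 1 (beyond the scatter) seen for compound 1, a step of a number 1.10 log units lower from compound 3 to compound 4 (beyond the scatter) is expected. Compound 4 is therefore estimated at 2, with a likely range from 1.7 to 2.3.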

Compound 4, partition coefficient: 1.9
Compound 4: the middle estimate sits 0.10 log units above what was measured; low and high end bracket the measured number.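

In this assay, oxolan-3-yl in place of 3,3,3-trifluoropropyl gave a number 1.20 log units lower from compound 3 to compound 4 (beyond the scatter) and, on the core carrying fluoro, a number 1.10 log units lower from compound 2 to compound 1 (beyond the scatter) in the same direction, so the change carried across these two cores. Hydrogen in place of fluoro gave a number 0.10 log units lower from compound 1 to compound 4 (within the scatter) with oxolan-3-yl on the nitrogen, and no change at the digits printed from compound 2 to compound 3 (within the scatter) with 3,3,3-trifluoropropyl there, but this single pair of cores does not show that the step would hold on a core altered elsewhere. Nothing given here explains the size of the step. Going by these compounds, whether it holds for a longer chain or an amine on that nitrogen remains open. So does its behaviour with chloro or methoxy in place of fluoro on the aromatic carbon.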